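Swapping a Dichlorobenzyl for a Methoxybenzyl on One Core

The source may hold more compounds than are shown below. What is called first, only, known or untested is meant among the compounds shown, and "the series" means these compounds.

Measured compounds:
compound 1 `Nc1cc(N)c2nc(-c3ccccc3)c(NCc3ccc(Cl)c(Cl)c3)nc2c1` — 40700 nM
compound 2 `CCOC(=O)[C@H](CCC(=O)O)NC(=O)c1ccc(Oc2nc3cc(N)cc(N)c3nc2-c2ccccc2)cc1` — < 100000 nM

Going by the values given here, in a functional assay on OVCAR-5 cells (Homo sapiens) for inhibition, read by sulforhodamine B assay, with a stated time of 48 h (a higher number here means a weaker inhibitor of growth, a lower number a stronger inhibitor of growth), compound 1 gives 40700 nM, the only plain number among the two values shown. Compound 2 reaches only a limit of the assay in this assay, < 100000 nM. That limit is the one named in the limit of < 100000 nM in this assay, at which 1 of the 2 values shown sits, so compound 1 stands alone as the single measured point to work from.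

Compound 3 `COc1ccc(CNc2nc3cc(N)cc(N)c3nc2-c2ccccc2)cc1` keeps the shared core of compound 1 and changes one group: 4-methoxyphenyl in place of 3,4-dichlorophenyl on a saturated chain carbon bound to a nitrogen on an aromatic ring. Among the compounds with values here, no measured pair shows what such a change does here, so the expectation rests on compound 1 alone. The step of a 1.4-fold higher number from compound 1 to compound 3 (0.13 log units; within the scatter) is expected to be small, in the direction of weaker growth inhibition, and may well sit within the usual scatter. Compound 3 is therefore estimated at 55000 nM, with a likely range from 18000 nM to 120000 nM.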

Compound 3, concentration for total growth inhibition: 45700 nM
Compound 3: the middle estimate sits 1.2-fold (0.08 log units) above what was measured; low and high end bracket the measured number.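

In this assay, going by these compounds alone, the one step at this position reads a 1.1-fold higher number from compound 1 to compound 3 (0.05 log units; within the scatter), with 4-methoxybenzyl in place of 3,4-dichlorobenzyl on the same core. Within the data shown here, until now, no measured pair showed what a change on this saturated chain carbon does; this first pair shows that the ring's two chlorine atoms and a methoxy group give readings that cannot be told apart from scatter. Nothing in the data shown explains this match.

The compounds shown leave open what a plain benzyl group, with no group on its ring, or a longer chain such as 2-phenylethyl would do at this position. They also leave open how a carboxylic acid or an amine on this ring would read in this assay.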